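This account rests on a few compounds, and the source may have more. Where it says the series, first, only, none or still open, it means among the compounds named here.

Working notes on the series. Four compounds share a core: compound 1 `COc1cc(NC(=O)/C=C/c2ccccc2C(F)(F)F)cc(OC)c1OC`, compound 2 `COc1ccc(NC(=O)/C=C/c2ccccc2C(F)(F)F)cc1OC`, compound 3 `COc1ccc(NC(=O)/C(C#N)=C/c2ccccc2C(F)(F)F)cc1` and the not yet measured compound 4 `COc1ccc(NC(=O)/C(C#N)=C/c2ccccc2C(F)(F)F)cc1OC`.

In an ADME assay on HBZY-1 cells (Rattus norvegicus) for cytotoxicity, read by MTT assay, with a stated time of 2 h (on this read-out higher numbers stand for weaker inhibition and lower numbers for stronger inhibition), compound 1 reaches only the limit of the assay, > 200000 nM. Compound 2 likewise gives only a limit in this assay, > 200000 nM. Compound 3 also stops at a limit in this assay, > 200000 nM. Every measured value therefore sits at the limit of > 200000 nM in this assay, at which 3 of the 3 values shown sit, and no number is known for any of the three.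

Going by the values given here, the one step that can be compared is methoxy in place of hydrogen on an aromatic carbon, which in this assay gives a step that the two limits leave unreadable from compound 2 to compound 1. How the cores of compound 2 and compound 3 differ is not broken down here.

The change from compound 3 to compound 4 is methoxy in place of hydrogen on an aromatic carbon. It is the same kind of change as that from compound 2 to compound 1, not the same: in compound 1 the entering group is additionally meta to a methoxy group, which it is not in compound 4.

Because the limit of > 200000 nM in this assay, at which 3 of the 3 values shown sit, holds all three measured values, and because a step that the two limits leave unreadable from compound 2 to compound 1 gives no readable size for the comparable step, the expectation for compound 4 in this assay rests only on the limit shared by the series. Compound 4 is expected to give about 250000 nM in this assay, most likely again reported as a limit. The expected step is a step that the limit leaves unreadable from compound 3 to compound 4, with the estimate for compound 4 spanning from 150000 nM to 600000 nM.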

Compound 4, half-maximal inhibitory concentration: > 200000 nM
Compound 4: no number, only a limit (the forecaster's own chance of this, stated with the estimate: 85%); the middle value lies beyond the limit too.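

Compound 4 also stops at a limit in this assay, so no size can be read for the step from compound 3 to compound 4. The whole series shares one boundary: the limit of > 200000 nM in this assay, at which 4 of the 4 values shown sit. The compounds shown leave open at what concentration, if any, members of this series would reach half-maximal inhibition in this assay, and what size methoxy in place of hydrogen on an aromatic carbon has there.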